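The compounds below may be only part of what the source reports. "The series", "measured", "known", "first", "only" and "open" are said of these compounds alone.

Measured compounds:
compound 1, `CC(C)c1noc(N2CCC(Oc3cc(N4CCc5cc([S+]([O-])CCO)ccc54)ncn3)CC2)n1`, 48 nM
compound 2, `CC(C)SC(=O)N1CCC(Oc2cc(N3CCc4cc(S(C)(=O)=O)ccc43)ncn2)CC1`, 3.2 nM

Both were tested in an assay on CHO cells for agonist activity at Glucose-dependent insulinotropic receptor (Homo sapiens), read by a luciferase reporter and cAMP accumulation, with a stated time of 2 h; a lower number here means that less compound is needed, a higher number that more compound is needed for the effect. Of the two numbers, compound 1 holds the higher one: compound 1 gives 48 nM, while compound 2 gives 3.2 nM, and the gap between them lies beyond the usual scatter. Compound 2 differs from compound 1 in more than one place, so its lower number cannot be tied to any single change.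

Compound 3, `CC(C)c1noc(N2CCC(Oc3cc(N4CCc5cc(N6CCCC6=O)ccc54)ncn3)CC2)n1`, has not yet been measured. It differs from compound 1 in one place: a group of 6 heavy atoms (4 carbon, 1 nitrogen, 1 oxygen; one five-membered non-aromatic ring with 1 hetero atom) in place of a group of 5 heavy atoms (2 carbon, 2 oxygen, 1 sulfur; no ring), on an aromatic carbon.

For the measured compounds named here, no measured pair shows a change of this kind, so the size of the step in this assay can only be guessed from compound 1 alone. The expected step is a 1.6-fold lower number from compound 1 to compound 3 (0.20 log units; within the scatter), a modest move toward a lower number that may well stay within the scatter. For compound 3 the estimated value in this assay is 30 nM, with a range from 8 nM to 120 nM.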

Compound 3, half-maximal effective concentration: 33 nM
For compound 3 the middle estimate is 1.1-fold (0.04 log units) below the measured one; measured number inside the range.
By their numbers in this assay, from the lowest: compound 2; then compounds 3 and 1 (each within the scatter of the next).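

In this assay, putting 2-oxopyrrolidin-1-yl in place of the open-chain sulfur group on this aromatic carbon gives a 1.5-fold lower number from compound 1 to compound 3 (0.16 log units; within the scatter) and so has no clear effect on the number. The position therefore accepts a five-membered non-aromatic ring, and neither the sulfur atom nor the hydrogen-bond donor of the departing group is needed to keep the number of compound 1 in this range. Nothing available explains why these two different groups give such similar numbers.

As far as these compounds go, it remains open how far this tolerance extends, for example to a simple amine or a carboxylic acid on the same aromatic carbon. A single step also cannot show whether this exchange would behave the same way with a different group elsewhere in the molecule.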